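Chain trimming on the shared core: compound 4

The source may report more compounds than this note shows. Statements on the series, on what has been measured and on what is new or still open speak of the compounds shown alone.

Compound 1 `CCCCc1c(OC)nc2nc(C(=O)c3ccccc3)cn2c1C` and compound 2 `CCc1c(OC)nc2nc(C(=O)c3ccccc3)cn2c1C` share one core; compound 3 `CCCc1cc(SC)nc2nc(C(=O)c3ccccc3)cn12` and the as yet unmeasured compound 4 `CSc1cc(C)n2cc(C(=O)c3ccccc3)nc2n1` share another. How the two cores differ is not broken down here. In a functional assay on the whole organism with Rattus norvegicus as the target (on this read-out higher numbers stand for an effect only at larger amounts of compound and lower numbers for an effect already at smaller amounts), compound 1 gives 2 mg/kg and compound 2 gives 2 mg/kg; the change between them, (hydrogen in place of ethyl on a saturated chain carbon, two bonds along the chain from an aromatic carbon), made the step of no change at the digits printed from compound 1 to compound 2 (within the scatter). In this assay compound 3 gives 10 mg/kg, a higher number than either. The change from compound 3 to compound 4, (hydrogen in place of ethyl on a saturated chain carbon bound to an aromatic carbon), is the same kind of change: ethyl leaves and hydrogen enters, but on a saturated chain carbon bound to an aromatic carbon rather than two bonds along the chain from an aromatic carbon. The step of no change at the digits printed from compound 3 to compound 4 (within the scatter) is expected from compound 3 to compound 4, resting on the flat step no change at the digits printed from compound 1 to compound 2 (within the scatter), widened since place and core both differ. Compound 4 is therefore estimated at 10 mg/kg in this assay, between 4 mg/kg and 30 mg/kg.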

Compound 4, minimum effective dose: 5 mg/kg
The estimate for compound 4 lay 2.0-fold (0.30 log units) above the measured number, and the stated range covers the measured number.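

In this assay, hydrogen in place of ethyl on a saturated chain carbon bound to an aromatic carbon gives a 2.0-fold lower number from compound 3 to compound 4 (0.30 log units; within the scatter). Set beside the same change two bonds along the chain from an aromatic carbon on the other core, this step shows no difference beyond the scatter: the same change on two cores in this assay, no change at the digits printed (within the scatter) from compound 1 to compound 2 and a 2.0-fold lower number (0.30 log units; within the scatter) from compound 3 to compound 4, 2.0-fold (0.30 log units) apart, within the scatter of two such steps. Within the data shown here, with a single pair on each core and the place differing between the pairs, this shows only that the two steps agree within the scatter, not that the change would behave alike on further cores or at other places.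

The compounds shown leave open how a longer chain, an amine or a carboxylic acid in place of the ethyl would read in this assay.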